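The compounds below may be only part of what the source reports. "The series", "measured", "known", "first", "only" and "open" are said of these compounds alone.

Measured compounds:
- compound 1 `CN(C[C@@H]1CCCc2cc(S(=O)(=O)c3cccc(F)c3)ccc21)S(N)(=O)=O`: 3.98 nM
- compound 2 `O=C(NC[C@@H]1CCCc2cc(S(=O)(=O)c3cccc(F)c3)ccc21)[C@H]1CCCN1`: 0.631 nM
- compound 3 `NC(=O)CNC[C@@H]1CCCc2cc(S(=O)(=O)c3cccc(F)c3)ccc21`: 0.1 nM

In an assay on isolated protein for displacement of a labelled ligand from 5-hydroxytryptamine receptor 6 (Homo sapiens) (a higher number here means a weaker inhibitor, a lower number a stronger inhibitor), compound 3 gives the lowest of the three numbers; its nearest neighbour is compound 2 and the step of a 6.3-fold lower number from compound 2 to compound 3 (0.80 log units; beyond the scatter) lies beyond the scatter, and compound 1 stands furthest, with a 40-fold lower number from compound 1 to compound 3 (1.60 log units; beyond the scatter) separating them. Compound 4 `NC(=O)NC[C@@H]1CCCc2cc(S(=O)(=O)c3cccc(F)c3)ccc21` is not yet measured. It differs from compound 3 at one place only: carbamoyl in place of carbamoylmethyl on an amine nitrogen. Going by the values given here, two measured steps bear on this position. In both a 40-fold lower number from compound 1 to compound 3 (1.60 log units; beyond the scatter) and a 6.3-fold lower number from compound 2 to compound 3 (0.80 log units; beyond the scatter), a group joined to that amine nitrogen through a carbonyl or a sulfonyl gave a higher number than the carbamoylmethyl group of compound 3. Compound 4 again carries a carbonyl-linked group, the carbamoyl, on that nitrogen, so a step back toward higher numbers is expected, of a size closer to a 6.3-fold lower number from compound 2 to compound 3 (0.80 log units; beyond the scatter) than to a 40-fold lower number from compound 1 to compound 3 (1.60 log units; beyond the scatter). The expected step is a 10-fold higher number from compound 3 to compound 4 (1.00 log units; beyond the scatter). Compound 4 is therefore estimated at 1 nM in this assay, within a range from 0.2 nM to 5 nM.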

Compound 4, inhibition constant: 0.2 nM
Estimate against measurement, compound 4: 5.0-fold (0.70 log units) above; measured number inside the range.
By their numbers in this assay, from the lowest: compounds 3 and 4 (each within the scatter of the next); then compound 2; then compound 1.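

In this assay, going by these compounds alone, the step of a 2.0-fold higher number from compound 3 to compound 4 (0.30 log units; within the scatter) shows that a carbonyl joined directly to the amine nitrogen does not by itself raise the number, which the earlier compounds could not separate. Compound 2 also has a carbonyl on that nitrogen, and the step of a 3.2-fold lower number from compound 2 to compound 4 (0.50 log units; beyond the scatter) shows that the group on the carbonyl carbon matters, with amino in place of pyrrolidin-2-yl. The ureido group also keeps a wide lead over methyl(sulfamoyl)amino, with a 20-fold lower number from compound 1 to compound 4 (1.30 log units; beyond the scatter); no measured evidence here explains any of these steps.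

The compounds shown leave open what an acetyl group would do on that amine nitrogen, which would test the amino part of the carbamoyl. They also leave open what a plain sulfamoyl group without the methyl would do there.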